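2-Fluorophenyl in place of 4-fluorophenyl in compound 4

A few compounds are considered here, and "the series" means these few. Any claim that something is new, unique, unknown or untested is made for them only; others in the source may bear on it.

In a functional assay on MCF7 cells (Homo sapiens) for antiproliferative activity, read by MTT assay, with a stated time of 72 h (a higher number here means a weaker inhibitor, a lower number a stronger inhibitor), compound 1 (`Cc1ccccc1N1CCN(C(=S)SCc2ccc3nc(N)nc(N)c3c2)CC1`) gives 4230 nM while compound 2 (`Nc1nc(N)c2cc(CSC(=S)N3CCN(c4ccccc4Cl)CC3)ccc2n1`) gives 3190 nM and compound 3 (`Nc1nc(N)c2cc(CSC(=S)N3CCN(c4ccc(F)cc4)CC3)ccc2n1`) gives 1920 nM as measured values. Within the data shown here, compound 3 stands clear of only one neighbour: a 2.2-fold lower number from compound 1 to compound 3 (0.34 log units; beyond the scatter) is the sole step beyond the scatter, and a 1.7-fold lower number from compound 2 to compound 3 (0.22 log units; within the scatter) stays inside it. Compound 4 (`Nc1nc(N)c2cc(CSC(=S)N3CCN(c4ccccc4F)CC3)ccc2n1`) carries 2-fluorophenyl in place of 4-fluorophenyl on an amine nitrogen in a ring. The 2-methylphenyl and 2-chlorophenyl groups hold that same place, and a 1.3-fold lower number from compound 1 to compound 2 (0.12 log units; within the scatter) separates them only slightly. Running those two steps to compound 3 backwards, a small rise, probably within the scatter, is expected in this assay for compound 4. The expected step is a 1.4-fold higher number from compound 3 to compound 4 (0.15 log units; within the scatter) in size. Compound 4 is estimated at 2700 nM with an expected range from 1300 nM to 5200 nM in this read-out.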

Compound 4, half-maximal inhibitory concentration: 4840 nM
Compound 4: the middle estimate sits 1.8-fold (0.25 log units) below what was measured, and the stated range covers the measured number.
By their numbers in this assay, from the lowest: compounds 3, 2, 1 and 4 (each within the scatter of the next, the first and the last beyond it).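

With the same atoms joined differently, moving the fluorine alone in this assay gives a 2.5-fold higher number from compound 3 to compound 4 (0.40 log units; beyond the scatter), so the place of this one atom on the phenyl ring matters here. The group at that place matters less: a 1.5-fold higher number from compound 2 to compound 4 (0.18 log units; within the scatter) and a 1.1-fold higher number from compound 1 to compound 4 (0.06 log units; within the scatter) leave the 2-fluorophenyl, 2-chlorophenyl and 2-methylphenyl compounds within the scatter of one another. Compound 2 goes against any clean split by position, as it lies within the scatter of compound 3 as well.

Nothing shown explains the effect of moving the fluorine. As far as these compounds go, whether an unsubstituted phenyl, a methoxyphenyl or a pyridine ring on that amine nitrogen would follow the same trend remains open.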